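Chloro on the Terminal Aniline of a Thiourea Chain

The source may report more compounds than this note shows. Statements on the series, on what has been measured and on what is new or still open speak of the compounds shown alone.

Compound 1 `NC(=S)Nc1cccc(OCCCCCc2ccccc2)c1` gives 22000 nM in an ADME assay on Huh-7 cells (Homo sapiens) for cytotoxicity; a lower number here means that less compound is tolerated, a higher number that more compound is tolerated.
Compound 2 `NC(=S)Nc1cccc(OCCCCCNC(=O)Nc2cccc3ccccc23)c1` gives > 50000 nM in this assay, a limit of the assay rather than a number.
Compound 3 `NC(=S)Nc1cccc(OCCCCCCCCNC(=S)Nc2ccccc2)c1` gives > 50000 nM in this assay, again a limit rather than a number.

Compound 3 therefore stands at the upper edge of what this assay reports, and it shares that position with the bulk of the set because of the limit of > 50000 nM in this assay, at which 2 of the 3 values shown sit. Compound 4 `NC(=S)Nc1cccc(OCCCCCCCCNC(=S)Nc2ccc(Cl)cc2)c1` is the next compound, built from compound 3 by one change: chloro in place of hydrogen on an aromatic carbon. No measured step exists for a change of this kind in this set, so the step is expected to stay within the scatter, most likely again at the limit. Compound 4 is estimated at 50000 nM, in a range from 20000 nM to 120000 nM, which means an expected step of a number no higher from compound 3 to compound 4 (the limit leaves the size open).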

Compound 4, half-maximal cytotoxic concentration: 18000 nM
The estimate for compound 4 lay 2.8-fold (0.44 log units) above the measured number, outside the stated range (below it).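

In this assay, chloro in place of hydrogen on the aromatic carbon para to a large group gives an at least 2.7-fold lower number from compound 3 to compound 4 (0.44 log units; beyond the scatter), so less compound is tolerated. Among these compounds, this is the first sign in the set that a single atom on this aniline ring can change the read-out. The true size of the step stays open because compound 3 sits at a limit: the limit of > 50000 nM in this assay, at which 2 of the 4 values shown sit.

From the compounds shown here alone, whether a fluoro group, a methoxy group or a carboxylic acid at this place would also lower the number remains open. So does whether the chloro has the same effect on a longer chain.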